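A few compounds are considered here, and "the series" means these few. Any claim that something is new, unique, unknown or untested is made for them only; others in the source may bear on it.

Compound 1 `CCc1ccc(C(=O)N2CCN(Cc3nc4ccccc4n3Cc3cccc(C)c3)CC2)cc1`: 67%
Compound 2 `O=C(C1CC1)N1CCN(Cc2nc3ccccc3n2Cc2ccccc2F)CC1`: 40.7%

In an assay on isolated protein for inhibition of aldehyde dehydrogenase 1A1 (Homo sapiens), read by spectrophotometry, tested at 10 uM (a lower number here means less inhibition, a higher number more inhibition at the concentration tested (going by the name of the read-out)), compound 1 gives 67% and compound 2 gives 40.7%. Compound 2 stands lowest of the two numbers; its nearest neighbour, compound 1, lies higher by a margin beyond the usual scatter, so the two do differ. Compound 3 `Cc1ccccc1Cn1c(CN2CCN(C(=O)C3CC3)CC2)nc2ccccc21` is not yet measured in this assay. It differs from compound 2 in one place: methyl in place of fluoro on an aromatic carbon. Among the compounds with values here, no pair of measured compounds shows this change on its own, since compound 1 and compound 2 differ in several places at once, so there is no measured step to lean on. The swap is small in size, and the step is expected to stay within the scatter, with no clear direction: a number 3.3 percentage points higher from compound 2 to compound 3 (within the scatter). Compound 3 is therefore estimated at 44%, expected to fall between 25% and 63%.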

Compound 3, a percentage reported as inhibition, at one concentration (the size of the read-out at that concentration, not a potency): 29.1%
Beside the measured number, compound 3's estimate is 14.9 percentage points above it, within the range that was stated.
By their numbers in this assay, from the lowest: compound 3; then compound 2; then compound 1.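

In this assay the change from 2-fluorobenzyl to 2-methylbenzyl gives a number 11.6 percentage points lower from compound 2 to compound 3 (beyond the scatter) and so shows that this position, on an aromatic carbon ortho to a large group, responds to swapping one heavy atom for another. Within this pair, fluoro gives more inhibition than methyl at the concentration tested, which is the first reading of a single change, as compound 1 and compound 2 differ in several places at once. The data at hand offer no measured explanation for this step.

From the compounds shown here alone, whether a chloro, a methoxy or a plain hydrogen at this place would read higher or lower remains open. So does whether the same swap would give a similar step with the amide group of compound 1 in place of the one carried by compound 2.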